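Moving the Methoxy Group: Compound 2 to Compound 3

The source may hold more compounds than are shown below. What is called first, only, known or untested is meant among the compounds shown, and "the series" means these compounds.

Of the compounds shown here, two have been measured. Compound 1 `Cc1c(/N=C/c2cccc(O)c2)c(=O)n(-c2ccccc2)n1C` gives 372000000 nM in a functional assay on DLD-1 cells (Homo sapiens) for cytotoxicity, read by MTT assay, with a stated time of 72 h; on this read-out lower numbers stand for stronger inhibition and higher numbers for weaker inhibition. Among the measured compounds shown here, compound 2 `COc1cccc(/C=N/c2c(C)n(C)n(-c3ccccc3)c2=O)c1` gives 832000000 nM in this assay, the highest of the two numbers; the only measured step, a 2.2-fold higher number from compound 1 to compound 2 (0.35 log units; beyond the scatter), concerns methyl in place of hydrogen on an oxygen. Compound 3 `COc1ccccc1/C=N/c1c(C)n(C)n(-c2ccccc2)c1=O` differs from compound 2 by 2-methoxyphenyl in place of 3-methoxyphenyl on a carbon with a double bond to nitrogen. For the measured compounds named here, no measured step changes where a group sits on a ring, so nothing here tells the direction of this change. The expected step is a 1.0-fold lower number from compound 2 to compound 3 (0.02 log units; within the scatter), within the usual scatter. Compound 3 is therefore estimated at 800000000 nM, between 300000000 nM and 2500000000 nM.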

Compound 3, half-maximal inhibitory concentration: 933000000 nM
Compound 3: the middle estimate sits 1.2-fold (0.07 log units) below what was measured; the range from low to high includes it.
By their numbers in this assay, from the lowest: compound 1; then compounds 2 and 3 (each within the scatter of the next).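

In this assay, 2-methoxyphenyl in place of 3-methoxyphenyl gives a 1.1-fold higher number from compound 2 to compound 3 (0.05 log units; within the scatter) and so shows no readable effect of where the methoxy group sits on this ring, at least between these two compounds. Replacing the 3-hydroxyphenyl of compound 1 with 2-methoxyphenyl gives a 2.5-fold higher number from compound 1 to compound 3 (0.40 log units; beyond the scatter) and so leaves both methoxy compounds above compound 1. No evidence at hand explains these numbers. As far as these compounds go, what 2-hydroxyphenyl would give remains open, as does the effect of an amine or a carboxylic acid on this ring.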